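Ethyl to Isopropyl on Two Amide Cores

The source may hold more compounds than are shown below. What is called first, only, known or untested is meant among the compounds shown, and "the series" means these compounds.

Compound 1 `CCS(=O)(=O)Nc1ccc(CNC(=O)c2ccc(C(C)(C)C)cc2)c(Cl)c1` carries an ethylsulfonyl group, and compound 2 `CC(C)S(=O)(=O)Nc1ccc(CNC(=O)c2ccc(C(C)(C)C)cc2)c(Cl)c1` differs from it only by methyl in place of hydrogen on a saturated chain carbon bound to a saturated chain carbon and a sulfonyl sulfur. In an ADME assay on microsomes from liver (Rattus norvegicus, strain Sprague-Dawley) for metabolic stability, read by HPLC, using NADPH, with stated times of 5 min and 60 min, tested at 10 uM (on this read-out higher numbers stand for fast clearance and lower numbers for slow clearance), compound 1 gives 28 mL.min-1.g-1, while compound 2 gives 23 mL.min-1.g-1, so the step of a 1.2-fold lower number from compound 1 to compound 2 (0.09 log units; within the scatter). Compound 3 `CCOc1ccc(C(=O)NCc2ccc(NS(C)(=O)=O)cc2Cl)cc1` rests on a different core, and the difference between the two cores is not broken down here; in this assay compound 3 gives 12 mL.min-1.g-1. Compound 4 `CC(C)Oc1ccc(C(=O)NCc2ccc(NS(C)(=O)=O)cc2Cl)cc1` has not yet been measured and differs from compound 3 by methyl in place of hydrogen on a saturated chain carbon bound to an oxygen on an aromatic ring and a saturated chain carbon. This is the same kind of change as that between compound 1 and compound 2, though the surroundings differ: in the first pair the carbon is bound to a saturated chain carbon and a sulfonyl sulfur, in the second to an oxygen on an aromatic ring and a saturated chain carbon. The earlier step of a 1.2-fold lower number from compound 1 to compound 2 (0.09 log units; within the scatter) stayed within the usual scatter, so for compound 4 a step of similar size is expected, a 1.1-fold lower number from compound 3 to compound 4 (0.04 log units; within the scatter). Compound 4 is therefore estimated at 11 mL.min-1.g-1, with a likely range from 5 mL.min-1.g-1 to 24 mL.min-1.g-1.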

Compound 4, intrinsic clearance in microsomes: 12 mL.min-1.g-1
Beside the measured number, compound 4's estimate is 1.1-fold (0.04 log units) below it; measured number inside the range.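

In this assay, replacing ethoxy with isopropoxy gives no change at the digits printed from compound 3 to compound 4 (within the scatter). Set beside the matching ethyl to isopropyl change on the sulfonyl side of the other core, the two steps do not differ by more than the usual scatter of such measurements: the same change on two cores in this assay, a 1.2-fold lower number (0.09 log units; within the scatter) from compound 1 to compound 2 and no change at the digits printed (within the scatter) from compound 3 to compound 4, 1.2-fold (0.09 log units) apart, within the scatter of two such steps. So in these two pairs, adding this one methyl leaves the clearance reading within the scatter on either core, but two pairs with the carbon in different surroundings cannot show that the same would hold on further cores, nor do they explain why the reading stays put.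

The compounds shown leave open how a longer chain, such as butoxy, would read in this assay in place of the isopropoxy of compound 4. They also leave open whether an amine or a carboxylic acid at that place would move the clearance beyond the scatter.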